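Ethyl to isopropyl on the aromatic nitrogen

The source may report more compounds than this note shows. Statements on the series, on what has been measured and on what is new or still open speak of the compounds shown alone.

In an assay on isolated protein for inhibition of Gonadotropin-releasing hormone receptor (Rattus norvegicus) (on this read-out higher numbers stand for weaker inhibition and lower numbers for stronger inhibition), compound 2 `CCn1c(SCc2cc([N+](=O)[O-])ccc2OC)nc2cc(NC(=O)NC(C)(C)C)ccc21` gives 170 nM, the lowest number of the three measured. Compound 1 `COc1ccc([N+](=O)[O-])cc1CSc1nc2cc(NC(=O)NC(C)(C)C)ccc2n1C1CC1` gives 860 nM and compound 3 `COc1ccc([N+](=O)[O-])cc1CSc1nc2cc(NC(=O)NC(C)(C)C)ccc2n1Cc1ccccn1` gives 670 nM. Compound 4 `COc1ccc([N+](=O)[O-])cc1CSc1nc2cc(NC(=O)NC(C)(C)C)ccc2n1C(C)C` carries methyl in place of hydrogen on a saturated chain carbon bound to an aromatic nitrogen and a saturated chain carbon. Among the measured compounds shown here, two measured steps bear on this position: a 5.1-fold lower number from compound 1 to compound 2 (0.70 log units; beyond the scatter), and a 3.9-fold higher number from compound 2 to compound 3 (0.60 log units; beyond the scatter). Both show that changes at the group on the aromatic nitrogen move the number beyond the scatter, and both leave compound 2 with the lowest number, so a further change here is more likely to raise the number than lower it. The step expected here is a 2.4-fold higher number from compound 2 to compound 4 (0.37 log units; beyond the scatter), upward and of modest size. Compound 4 is therefore expected at 400 nM, within a range from 150 nM to 1100 nM.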

Compound 4, half-maximal inhibitory concentration: 62 nM
Compound 4: middle estimate off by 6.5-fold (0.81 log units), on the high side, outside the stated range (below it).
By their numbers in this assay, from the lowest: compound 4; then compound 2; then compounds 3 and 1 (each within the scatter of the next).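

In this assay, ethyl to isopropyl gives a 2.7-fold lower number from compound 2 to compound 4 (0.44 log units; beyond the scatter) and so shows that the group on the aromatic nitrogen can go lower than compound 2. The wider steps, an 11-fold lower number from compound 3 to compound 4 (1.03 log units; beyond the scatter) and a 14-fold lower number from compound 1 to compound 4 (1.14 log units; beyond the scatter), show that isopropyl and cyclopropyl are far apart at this position, as are isopropyl and (pyridin-2-yl)methyl. Nothing at hand accounts for these steps.

Open, from the compounds shown here alone, is how tert-butyl, a longer chain such as n-propyl, or a chain ending in an amine would read here. Also open, going by these compounds, is whether the isopropyl gain holds with other groups elsewhere on the shared core.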